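A few compounds are considered here, and "the series" means these few. Any claim that something is new, unique, unknown or untested is made for them only; others in the source may bear on it.

Compound 1 `Cn1cc(C2CC(c3ccccc3)=NN2C(=O)c2cccnc2)c2cc(Br)ccc21` gives 2520 nM in a functional assay on HepG2 cells (Homo sapiens) for inhibition, read by MTT assay, with a stated time of 48 h; on this read-out lower numbers stand for stronger inhibition of growth and higher numbers for weaker inhibition of growth.
Compound 2 `Cn1cc(C2CC(c3ccc(Br)cc3)=NN2C(=O)c2cccnc2)c2cc(Br)ccc21` gives 6910 nM.
Compound 3 `COc1ccc(C2=NN(C(=O)c3cccnc3)C(c3cn(C)c4ccc(Br)cc34)C2)cc1` gives 540 nM.

Compound 1 and compound 2 share a core and differ in one place: hydrogen in place of bromo on an aromatic carbon. That change is read in a 2.7-fold higher number from compound 1 to compound 2 (0.44 log units; beyond the scatter). Compound 3 carries a methoxy where compound 1 has hydrogen, and a 4.7-fold lower number from compound 1 to compound 3 (0.67 log units; beyond the scatter) follows. Between compound 2 and compound 3 the difference is methoxy in place of bromo on an aromatic carbon, and the step is a 13-fold lower number from compound 2 to compound 3 (1.11 log units; beyond the scatter).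

Compound 4 `COc1ccc2c(c1)c(C1CC(c3ccccc3)=NN1C(=O)c1cccnc1)cn2C` has not yet been measured. It differs from compound 1 by methoxy in place of bromo on an aromatic carbon. This is the same kind of change as that from compound 2 to compound 3, but not the same: there the place is para to a large group, whereas here the aromatic carbon belongs to a ring that is part of a fused or bridged system of two rings, meta to a fused ring and para to a fused ring. The expectation for compound 4 rests on the direction of a 13-fold lower number from compound 2 to compound 3 (1.11 log units; beyond the scatter), tempered by the different place; the step is expected to be a 2.1-fold lower number from compound 1 to compound 4 (0.32 log units; beyond the scatter). Compound 4 is therefore estimated to give 1200 nM.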

Compound 4, concentration for 50% growth inhibition: 5110 nM
Estimate against measurement, compound 4: 4.3-fold (0.63 log units) below; the measured number lies above the stated range.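

In this assay, methoxy in place of bromo on the fused two-ring system gives a 2.0-fold higher number from compound 1 to compound 4 (0.31 log units; beyond the scatter), so the change does not keep the direction it has at the other place. Set side by side, the two instances of the change disagree: the same change on two cores in this assay, a 13-fold lower number (1.11 log units; beyond the scatter) from compound 2 to compound 3 and a 2.0-fold higher number (0.31 log units; beyond the scatter) from compound 1 to compound 4, 26-fold (1.41 log units) apart, beyond the scatter of two such steps. This shows that, in this series, the result of this change cannot be carried from one core to another, even in direction; it does not show why, and since the two steps differ both in the place of the change and in the rest of the molecule, two instances cannot separate the influence of one from the other.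

From the compounds shown here alone, what an amine, a carboxylic acid or a longer chain would give at that aromatic carbon in place of bromo remains open. Going by these compounds, it also remains open whether the step from bromo to methoxy at that carbon would keep its direction on the core of compound 3, where a methoxy is already present.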